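Chloro for methoxy on the allyl amide pair

A few compounds are considered here, and "the series" means these few. Any claim that something is new, unique, unknown or untested is made for them only; others in the source may bear on it.

Working notes on a short series of aryl-propenamides. Compound 3 `C=CCNC(=O)/C(C)=C(\C)c1ccc(OC)cc1` carries a methoxy on the aromatic ring and an allyl amide. In a toxicity assay on the whole organism (strain Icem-CET (SPF Caw)) for cytotoxicity, with Mus musculus as the target (on this read-out higher numbers stand for an effect only at larger amounts of compound and lower numbers for an effect already at smaller amounts), compound 3 gives 300 mg/kg. Compound 2 `C=CCNC(=O)/C(C)=C(\C)c1ccccc1`, the unsubstituted parent of that amide, gives 250 mg/kg in this assay, and compound 1 `C/C(C(=O)NC1CC1)=C(/C)c1ccc(Cl)cc1`, a chloro analogue with a cyclopropyl amide, gives 150 mg/kg. Compound 3 is separated from compound 2 and from compound 1 only by gaps within the scatter.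

The next compound, compound 4 `C=CCNC(=O)/C(C)=C(\C)c1ccc(Cl)cc1`, differs from compound 3 by chloro in place of methoxy on an aromatic carbon.

For the measured compounds named here, only one single-point step is available: a 1.2-fold higher number from compound 2 to compound 3 (0.08 log units; within the scatter), which shows that adding methoxy moved nothing beyond the scatter. Going by the values given here, no single-point step exchanges chloro for methoxy. Compound 1 and compound 3, which share only the ring substituent question but differ in the amide, show the chloro compound with the lower number. The expected outcome is therefore a small drop, a 1.5-fold lower number from compound 3 to compound 4 (0.18 log units; within the scatter), not expected to exceed the scatter. For compound 4 the estimate in this assay is 200 mg/kg, with a range from 120 mg/kg to 350 mg/kg.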

Compound 4, dose for half-maximal effect: 70 mg/kg
Beside the measured number, compound 4's estimate is 2.9-fold (0.46 log units) above it, outside the stated range (below it).
By their numbers in this assay, from the lowest: compound 4; then compounds 1, 2 and 3 (each within the scatter of the next).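

In this assay, the aromatic carbon para to a large group turns out to respond to the choice of group: chloro in place of methoxy gives a 4.3-fold lower number from compound 3 to compound 4 (0.63 log units; beyond the scatter), and chloro in place of hydrogen gives a 3.6-fold lower number from compound 2 to compound 4 (0.55 log units; beyond the scatter), whereas methoxy in place of hydrogen gives only a 1.2-fold higher number from compound 2 to compound 3 (0.08 log units; within the scatter). On the allyl amide, the outcome at this carbon therefore depends on which group sits there, and of hydrogen, methoxy and chloro, only chloro moves the number beyond the scatter. With chloro held fixed, the amide also matters: allyl in place of cyclopropyl on the nitrogen gives a 2.1-fold lower number from compound 1 to compound 4 (0.33 log units; beyond the scatter).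

Going by these compounds, whether a fluoro, a nitrile or a trifluoromethyl at this carbon would follow chloro, and whether a longer chain on the amide nitrogen would lower the number further, stays open. Nothing available on these compounds speaks to why chloro and methoxy part here.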